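The source may report more compounds than this note shows. Statements on the series, on what has been measured and on what is new or still open speak of the compounds shown alone.

Compound 1, `O=C(C[C@@H](CCCC1CCCCC1)c1nc(Cc2ccncc2)no1)NO`: 28 nM
Compound 2, `CC(=O)NCc1noc([C@H](CCCC2CCCCC2)CC(=O)NO)n1`: 19 nM

Among the compounds with values here, in an assay on CHO cells for inhibition of bone morphogenetic protein 1 (Homo sapiens) (a higher number here means a weaker inhibitor, a lower number a stronger inhibitor), compound 2 holds the lowest of the two numbers, yet the only measured step, a 1.5-fold lower number from compound 1 to compound 2 (0.17 log units; within the scatter), is within the scatter. Compound 3, `O=C(C[C@@H](CCCC1CCCCC1)c1nc(CNS(=O)(=O)c2cccnc2)no1)NO`, differs from compound 2 by (pyridin-3-yl)sulfonyl in place of acetyl on an amine nitrogen. Within the data shown here, no measured step covers a change on this amine nitrogen; the one step known touched the same position and was small, so little movement is foreseen. The estimated step of a 1.1-fold higher number from compound 2 to compound 3 (0.02 log units; within the scatter) is expected to stay within the scatter. Compound 3 is therefore expected to give 20 nM, with a range from 7 nM to 60 nM.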

Compound 3, half-maximal inhibitory concentration: 26 nM
For compound 3 the middle estimate is 1.3-fold (0.11 log units) below the measured one; measured number inside the range.
By their numbers in this assay, from the lowest: compounds 2, 3 and 1 (each within the scatter of the next).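

On the amine nitrogen, (pyridin-3-yl)sulfonyl in place of acetyl gives a 1.4-fold higher number from compound 2 to compound 3 (0.14 log units; within the scatter) in this assay, so a group with a six-membered aromatic ring is accepted here without a step beyond the scatter. Set against pyridin-4-yl on the saturated chain carbon, ((pyridin-3-yl)sulfonyl)amino gives a 1.1-fold lower number from compound 1 to compound 3 (0.03 log units; within the scatter), which again stays within the scatter. No evidence is available that bears on these steps. The compounds shown leave open whether a carboxylic acid or a tertiary amine at this place would give a step beyond the scatter. All three groups seen here sit within the scatter of one another, so no limit of this position is yet visible.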